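Swapping the amine at the chain end of a coumarin amide

The source may hold more compounds than are shown below. What is called first, only, known or untested is meant among the compounds shown, and "the series" means these compounds.

For the measured compounds named here, compound 2 `CC(C)=CCc1cc(C(=O)Nc2cc3ccc(OCCCN(C)C(C)(C)C)c(C)c3oc2=O)ccc1O` is one of two compounds measured in a functional assay on MCF7 cells (Homo sapiens) for antiproliferative activity; on this read-out higher numbers stand for weaker inhibition and lower numbers for stronger inhibition. Compound 2 gives 1140 nM, and its close relative compound 1 `CC(C)=CCc1cc(C(=O)Nc2cc3ccc(OCC4CCCNC4)c(C)c3oc2=O)ccc1O` gives 790 nM; the step of a 1.4-fold higher number from compound 1 to compound 2 (0.16 log units; within the scatter) shows that changing the amine at the end of the chain left the result within the scatter. Compound 3 `CC(C)=CCc1cc(C(=O)Nc2cc3ccc(OCCCN[C@H](C)c4ccccc4)c(C)c3oc2=O)ccc1O` has not yet been measured. It differs from compound 2 by (1-phenylethyl)amino in place of methyl(tert-butyl)amino on a saturated chain carbon, three bonds along the chain from an oxygen on an aromatic ring. Going by the values given here, the only comparable step is the one from compound 1 to compound 2, which also altered the amine-bearing end of the chain and moved the number hardly at all, so no shift beyond the scatter is expected in this assay for compound 3 either. Compound 3 is therefore expected to give about 900 nM, most likely between 350 nM and 2500 nM. The step expected from compound 2 to compound 3 is a 1.3-fold lower number from compound 2 to compound 3 (0.10 log units; within the scatter).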

Compound 3, half-maximal inhibitory concentration: 1450 nM
Estimate against measurement, compound 3: 1.6-fold (0.21 log units) below; the range from low to high includes it.
By their numbers in this assay, from the lowest: compounds 1, 2 and 3 (each within the scatter of the next).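

In this assay, putting (1-phenylethyl)amino in place of methyl(tert-butyl)amino gives a 1.3-fold higher number from compound 2 to compound 3 (0.10 log units; within the scatter), so at this position an added six-membered aromatic ring, a hydrogen-bond donor and a defined stereocentre come with no shift beyond the scatter. Measured against the piperidin-3-yl of compound 1, the open 2-((1-phenylethyl)amino)ethyl group gives a 1.8-fold higher number from compound 1 to compound 3 (0.26 log units; within the scatter), which means that all three amine ends seen so far lie within the scatter of one another. Nothing measured here offers an explanation for this flat result.

The compounds shown leave open how the mirror-image form of the (1-phenylethyl)amino group would read. They also leave open whether a carboxylic acid in place of the amine, or a longer chain, would move the number beyond the scatter.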